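Methyl removal from the chain in a methyltransferase binder series

This account rests on a few compounds, and the source may have more. Where it says the series, first, only, none or still open, it means among the compounds named here.

Measured so far:
compound 1 `CCCCN1/C(=C/C(C)=C/c2sc3ccccc3[n+]2CCCC)Sc2ccccc21`: 77%
compound 2 `CCN1/C(=C/C=C/c2sc3cc(Br)ccc3[n+]2CC)Sc2cc(Br)ccc21`: 88%
compound 3 `CN1/C(=C/C=C/C2=[N+](CCCc3ccccc3)c3ccccc3C2(C)C)C(C)(C)c2ccccc21`: 35%

In an assay for displacement of a labelled ligand from protein arginine N-methyltransferase 1 (Homo sapiens), read by scintillation proximity assay, with stated times of 5 min and 8 min, tested at 10 uM (on this read-out lower numbers stand for a weaker effect and higher numbers for a stronger effect at the one concentration tested), compound 1 gives 77%, the second highest of the three numbers. Compound 2 stands higher, by a gap beyond the scatter, and compound 3 stands lower, by a gap well beyond the scatter. Among the measured compounds shown here, no pair of measured compounds differs in a single place, so no step size is known.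

Compound 4 `CCCCN1/C(=C/C=C/c2sc3ccccc3[n+]2CCCC)Sc2ccccc21` is not yet measured. It differs from compound 1 in one place: hydrogen in place of methyl on a double-bonded chain carbon bound to two double-bonded chain carbons. Compound 2 also carries no methyl on its chain but differs from compound 4 elsewhere, so the value of compound 2, 88%, only loosely supports the unmethylated chain. The step of a number 3 percentage points higher from compound 1 to compound 4 (within the scatter) is expected to stay within the scatter, at most slightly upward. Compound 4 is estimated at 80%, in the range 62% to 93%.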

Compound 4, a percentage reported as inhibition, at one concentration (the size of the read-out at that concentration, not a potency): 79%
Compound 4: the middle estimate sits 1 percentage points above what was measured; measured number inside the range.
By their numbers in this assay, from the lowest: compound 3; then compounds 1, 4 and 2 (each within the scatter of the next, the first and the last beyond it).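

In this assay, hydrogen in place of methyl on a double-bonded chain carbon bound to two double-bonded chain carbons gives the first step known in the series, a number 2 percentage points higher from compound 1 to compound 4 (within the scatter), with the rest of the structure unchanged. At this one concentration, the methyl at this position is therefore not required for the read-out. Nothing at hand bears on why the two compounds read alike.

From the compounds shown here alone, whether an ethyl, a methoxy or an amine at the same carbon would also leave the read-out unmoved remains open. A single concentration also leaves any potency difference between compound 1 and compound 4 unresolved.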